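The compounds below may be only part of what the source reports. "The series", "measured", "known", "first", "only" and "open" are said of these compounds alone.

Working notes on the series. Compound 1 `Nc1nc(SCc2ccccc2)nc2c1nc(O)n2Cc1ccccc1`, compound 2 `CCNc1nc(N)c2nc(O)n(Cc3ccccc3)c2n1` and compound 3 `CCCc1nc(N)c2nc(O)n(Cc3ccccc3)c2n1` share one core and differ only in the group on a single aromatic carbon. In a functional assay (spleen, spleen) for activation, with Mus musculus as the target (a higher number here means that more compound is needed for the effect, a lower number that less compound is needed), compound 1 gives 0.1 uM, compound 2 gives 1 uM and compound 3 gives 1 uM. Compound 3 therefore stands level with compound 2 at the digits shown, the two together holding the highest numbers of the three; the step of no change at the digits printed from compound 2 to compound 3 (within the scatter) lies within the scatter, whereas a 10-fold higher number from compound 1 to compound 3 (1.00 log units; beyond the scatter) and a 10-fold higher number from compound 1 to compound 2 (1.00 log units; beyond the scatter) both lie beyond it.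

Compound 4 `CCCCCSc1nc(N)c2nc(O)n(Cc3ccccc3)c2n1` has not been measured. It follows from compound 3 by pentylsulfanyl in place of propyl on an aromatic carbon. For the measured compounds named here, the only measured step that involves a sulfanyl group at this carbon is a 10-fold higher number from compound 1 to compound 3 (1.00 log units; beyond the scatter); read in reverse, replacing propyl by benzylsulfanyl lowered the number by a modest but clear amount. Pentylsulfanyl is not benzylsulfanyl, so only part of that step is expected to carry over, and the numbers for compound 2 and compound 3 give no further guidance. The expected step is a 3.3-fold lower number from compound 3 to compound 4 (0.52 log units; beyond the scatter), toward the number of compound 1. Compound 4 is thus estimated at 0.3 uM in this assay, within the range 0.1 uM to 1 uM.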

Compound 4, minimum effective concentration: 10 uM
Compound 4: middle estimate off by 33-fold (1.52 log units), on the low side; the measured number lies above the stated range.
By their numbers in this assay, from the lowest: compound 1; then compounds 2 and 3 (each within the scatter of the next); then compound 4.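

At this carbon, which lies between two ring nitrogen atoms, a sulfur link does not by itself bring a lower number in this assay: pentylsulfanyl gives a step in the opposite direction from benzylsulfanyl, both against propyl (a 10-fold higher number from compound 3 to compound 4 (1.00 log units; beyond the scatter)) and against ethylamino (a 10-fold higher number from compound 2 to compound 4 (1.00 log units; beyond the scatter)). For the compounds shown here, the group carried on the sulfur therefore decides the outcome, as the two sulfanyl compounds show (a 100-fold higher number from compound 1 to compound 4 (2.00 log units; beyond the scatter)), with butyl in place of phenyl on a saturated chain carbon bound to a sulfur as the only change. Nothing measured for these compounds bears on the reason for these steps.

Going by these compounds alone, with only two sulfanyl compounds, it remains open whether the low number of compound 1 depends on the phenyl ring itself or would also be reached with a cyclohexylmethylsulfanyl or 2-phenylethylsulfanyl group. From the compounds shown here alone, it is equally open how the number moves along the straight chains, since a propylsulfanyl or a longer octylsulfanyl group would show whether chain length matters at this carbon or whether any chain without a ring gives a high number.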